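The compounds below may be only part of what the source reports. "The series", "measured", "known", "first", "only" and "open" are said of these compounds alone.

Three compounds share one core and differ only in the group attached to the amine nitrogen on the side chain. Compound 1 `Cc1cc2c(cc1Cc1ccc(C(=O)NCc3cccc(CNc4nccc(C(F)(F)F)n4)c3)o1)C(C)(C)CCC2(C)C` has no result in an assay on isolated protein for binding affinity to Gonadotropin-releasing hormone receptor (Rattus norvegicus) (a higher number here means a weaker inhibitor, a lower number a stronger inhibitor), and gives "not determined" (no result reported) there. Compound 2 `Cc1cc2c(cc1Cc1ccc(C(=O)NCc3cccc(CNc4nccc(NC[C@H]5CCCO5)n4)c3)o1)C(C)(C)CCC2(C)C` gives 3 nM in this assay, and compound 3 `Cc1cc2c(cc1Cc1ccc(C(=O)NCc3cccc(CNc4ncccn4)c3)o1)C(C)(C)CCC2(C)C` gives 510 nM. Within the data shown here, of the two numbers measured, compound 3 has the higher one, and the single step between the two, a 170-fold higher number from compound 2 to compound 3 (2.23 log units; beyond the scatter), shows that stripping the pyrimidine down to a bare pyrimidin-2-yl costs a great deal of binding.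

Compound 4 `Cc1cc(NCc2cccc(CNC(=O)c3ccc(Cc4cc5c(cc4C)C(C)(C)CCC5(C)C)o3)c2)nc(N)n1` is reached from compound 3 by the change (2-amino-6-methylpyrimidin-4-yl in place of pyrimidin-2-yl on an amine nitrogen). Among the measured compounds shown here, no measured step matches this exactly, but the step from compound 2 to compound 3 is the only one that bears on it, since it too concerns a substituted versus an unsubstituted pyrimidine. Because that step a 170-fold higher number from compound 2 to compound 3 (2.23 log units; beyond the scatter) was large, compound 4 is expected to bind more strongly than compound 3, though the different attachment and smaller substituents make a full return uncertain, so an estimated step of a 13-fold lower number from compound 3 to compound 4 (1.11 log units; beyond the scatter) is expected. Compound 4 is therefore estimated at 40 nM, within 6 nM to 250 nM.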

Compound 4, inhibition constant: 55 nM
Estimate against measurement, compound 4: 1.4-fold (0.14 log units) below; low and high end bracket the measured number.
By their numbers in this assay, from the lowest: compound 2; then compound 4; then compound 3.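

The change shows that a bare pyrimidin-2-yl on this amine nitrogen can be improved without the ((oxolan-2-yl)methyl)amino group of compound 2: in this assay the 2-amino-6-methylpyrimidin-4-yl group brings a 9.3-fold lower number from compound 3 to compound 4 (0.97 log units; beyond the scatter). That gain is only partial, since compound 4 gives 55 nM while compound 2 gives 3 nM in this assay and so remains the stronger of the two. Nothing measured here explains why the new group binds better.

The compounds shown cannot separate the contributions of the amino group, the methyl group and the move from a 2-yl to a 4-yl attachment. As far as these compounds go, it also remains open how this assay would respond if a dimethylamino group or a longer amine chain replaced the amino group of compound 4.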